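Alpha-ketooxazole series: pyridyl replaces carbamoylphenyl

The source may hold more compounds than are shown below. What is called first, only, known or untested is meant among the compounds shown, and "the series" means these compounds.

Measured compounds:
compound 1 `NC(=O)c1cccc(-c2cnc(C(=O)CCCCCCc3ccccc3)o2)c1` with 6 nM in an assay (Rattus norvegicus) for inhibition of Fatty-acid amide hydrolase 1 (Homo sapiens); on this read-out higher numbers stand for weaker inhibition and lower numbers for stronger inhibition
compound 2 `NC(=O)c1ccc(-c2cnc(C(=O)CCCCCCc3ccccc3)o2)cc1` with 10 nM in this assay

Within the data shown here, compound 2 carries the higher of the two numbers recorded in this assay; the only neighbour is compound 1, and the step of a 1.7-fold higher number from compound 1 to compound 2 (0.22 log units; within the scatter) lies within the scatter, so the two compounds are indistinguishable on this read-out. That step exchanges one carbamoylphenyl for another and is the whole of the measured record.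

Compound 3 `Cc1ccnc(-c2cnc(C(=O)CCCCCCc3ccccc3)o2)c1` has not been measured. It differs from compound 2 in one place: 4-methylpyridin-2-yl in place of 4-carbamoylphenyl on an aromatic carbon. Among the measured compounds shown here, no measured step touches this kind of exchange, in which the carbamoyl group and its hydrogen-bond donor are lost and a pyridine nitrogen enters. For the measured compounds named here, because the only step on record, a 1.7-fold higher number from compound 1 to compound 2 (0.22 log units; within the scatter), stayed inside the scatter, the account gives no reason to expect a large move, yet it also gives no guide for a group of a new kind. Compound 3 is therefore expected to stay close to compound 2, with a 1.3-fold lower number from compound 2 to compound 3 (0.10 log units; within the scatter) as the estimated step. The estimate for compound 3 in this assay is 8 nM, expected to fall between 2 nM and 30 nM.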

Compound 3, inhibition constant: 0.6 nM
Compound 3: the middle estimate sits 13-fold (1.12 log units) above what was measured; measured number below the stated range.
By their numbers in this assay, from the lowest: compound 3; then compounds 1 and 2 (each within the scatter of the next).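

The position on the aromatic carbon next to the ring oxygen now proves sensitive to the group it carries: in this assay, the exchange gives a 17-fold lower number from compound 2 to compound 3 (1.22 log units; beyond the scatter) and, against the other carbamoylphenyl, a 10-fold lower number from compound 1 to compound 3 (1.00 log units; beyond the scatter) on the same read-out, whereas moving the carbamoyl group around the phenyl ring had stayed within the scatter. Both steps also show that a low number at this position does not depend on the carbamoyl group or its hydrogen-bond donor, since 4-methylpyridin-2-yl has no donor and compound 3 carries the lowest number of the three. No independent measurement accompanies these compounds that could explain the size of either step.

The exchange changes several things at once, so these compounds cannot separate the contribution of the ring nitrogen from that of the methyl group or from the loss of the carbamoyl group. An unsubstituted pyridin-2-yl and a 4-methylphenyl at this position would divide that single step into its parts, and a 4-carboxyphenyl would show how far the result extends to a carboxylic acid.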